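Swapping nitro for amino on a dithiole core

The source may report more compounds than this note shows. Statements on the series, on what has been measured and on what is new or still open speak of the compounds shown alone.

Measured compounds:
- compound 1 `COc1ccc(-c2ssc(=S)c2-c2cc(OC)c(OC)c(OC)c2)cc1[N+](=O)[O-]`: 9140 nM
- compound 2 `COc1ccc(-c2ssc(=S)c2-c2cc(OC)c(OC)c(OC)c2)cc1N`: 834 nM
- compound 3 `COc1ccc(-c2ssc(=O)c2-c2cc(OC)c(OC)c(OC)c2)cc1[N+](=O)[O-]`: 4220 nM

Of the compounds shown here, three have been tested in a functional assay on HT-1080 cells (Homo sapiens) for antiproliferative activity, read by MTT assay, with a stated time of 72 h; a lower number here means a stronger inhibitor, a higher number a weaker inhibitor. Compound 1 gives 9140 nM, and compound 2, which differs from it in one place, gives 834 nM. The change between them is amino in place of nitro on an aromatic carbon, and it made a step of an 11-fold lower number from compound 1 to compound 2 (1.04 log units; beyond the scatter).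

Compound 3 carries a different core; how it differs from the core of compound 1 is not broken down here. In this assay compound 3 gives 4220 nM, a higher number than compound 2 and a lower one than compound 1.

The compound still to be measured is compound 4 `COc1ccc(-c2ssc(=O)c2-c2cc(OC)c(OC)c(OC)c2)cc1N`. It relates to compound 3 exactly as compound 2 relates to compound 1: the difference is amino in place of nitro on an aromatic carbon, the same change in the same kind of place. Only one earlier example of this change exists among these compounds, so the expectation rests on a single step. Because that earlier step was an 11-fold lower number from compound 1 to compound 2 (1.04 log units; beyond the scatter), the same change applied to compound 3 is expected to give a step of about a 9.4-fold lower number from compound 3 to compound 4 (0.97 log units; beyond the scatter) in this assay. The estimate for compound 4 in this assay is therefore 450 nM, with a likely range from 150 nM to 1500 nM.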

Compound 4, half-maximal inhibitory concentration: 147 nM
Compound 4: the middle estimate sits 3.1-fold (0.49 log units) above what was measured; measured number below the stated range.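

In this assay, amino in place of nitro on the second core gave a 29-fold lower number from compound 3 to compound 4 (1.46 log units; beyond the scatter), so the change lowers the number by a large step here too, as it did on the first core. Going by these compounds alone, the second step looks bigger, but that gap should not be read as a real difference, and on this evidence the change carried over from one core to the other with its size intact: the same change on two cores in this assay, an 11-fold lower number (1.04 log units; beyond the scatter) from compound 1 to compound 2 and a 29-fold lower number (1.46 log units; beyond the scatter) from compound 3 to compound 4, 2.6-fold (0.42 log units) apart, within the scatter of two such steps This is only two pairs of compounds on two closely related cores in a single cell assay, so it does not show that the step would hold on any other core, and it says nothing about why amino gives the lower number.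

What the compounds shown leave open is whether the low number needs amino itself, or whether a hydroxyl, a methylamino or an acetamide on the same aromatic carbon would give a similar result. They also leave open how the same swap would behave on a core that differs more from these two, or in cells other than the ones tested here.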